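Pyrazole change on the shared core: lipophilicity notes

The source may report more compounds than this note shows. Statements on the series, on what has been measured and on what is new or still open speak of the compounds shown alone.

Measured in a physicochemical assay for lipophilicity, using the shake flask method, in phosphate buffer, measured as octanol-water partition, with a stated time of 30 min, at pH 7.4; a higher number here means a more lipophilic compound, a lower number a more polar compound:
- compound 1 `Cn1nccc1-c1cnc(NCc2c(F)ccc3c2CCO3)c2cn[nH]c(=O)c12`: 2.6
- compound 2 `O=C1CCCN1c1cnc(NCc2c(F)ccc3c2CCO3)n2cnnc12`: 1.3

Compound 1 stands highest of the two numbers. The nearest is compound 2, whose value in this assay lies lower by a gap beyond the scatter; the two compounds differ in more than one place, so the gap cannot be tied to a single change and only the two values themselves are noted.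

Compound 3 `Cc1nn(C)cc1-c1cnc(NCc2c(F)ccc3c2CCO3)c2cn[nH]c(=O)c12` has not yet been measured in this assay. It differs from compound 1 in one place: 1,3-dimethyl-1H-pyrazol-4-yl in place of 1-methyl-1H-pyrazol-5-yl on an aromatic carbon

Among the compounds with values here, no pair of measured compounds differing in one place is available, so the size of the step from compound 1 to compound 3 has no direct precedent here. The change exchanges one group for another of similar kind with one more heavy atom, and the step is expected to be small and upward, at or just beyond the scatter: compound 3 is expected to show a number 0.30 log units higher from compound 1 to compound 3 (within the scatter). On that basis compound 3 is estimated at 2.9 in this assay, with a range from 2.5 to 3.3.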

Compound 3, distribution coefficient: 2.8
For compound 3 the middle estimate is 0.10 log units above the measured one, and the stated range covers the measured number.
By their numbers in this assay, from the lowest: compound 2; then compounds 1 and 3 (each within the scatter of the next).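

Within the data shown here, this is the first step that can be read at a single place: on an aromatic carbon of a six-membered aromatic ring of the shared core, 1,3-dimethyl-1H-pyrazol-4-yl in place of 1-methyl-1H-pyrazol-5-yl gives a number 0.20 log units higher from compound 1 to compound 3 (within the scatter) in this assay. At this position, then, one five-membered aromatic ring with 2 hetero atoms can be exchanged for another, going from 6 to 7 heavy atoms with the hydrogen-bond donor and acceptor counts unchanged, and the number stays within the usual scatter, so compound 1 and compound 3 cannot be placed in any order. No measurement available here bears on the reason for this step.

As far as these compounds go, whether the number stays within the scatter when a group of another kind, such as a carboxylic acid or a longer chain ending in an amine, stands at this place remains open. Also open, from the compounds shown here alone, is what any single change contributes to the gap to compound 2, which differs from compound 1 in more than one place.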